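Para substituent swap on the sulfonylphenyl arm

This account rests on a few compounds, and the source may have more. Where it says the series, first, only, none or still open, it means among the compounds named here.

Three compounds sharing one core have numbers in a functional assay on PC-3 cells (Homo sapiens) for inhibition; a lower number here means a stronger inhibitor, a higher number a weaker inhibitor. Compound 1 `COc1cc2nc(N3CCN(S(=O)(=O)c4cccc([N+](=O)[O-])c4)CC3)nc(N)c2cc1OC` gives 32000 nM. Compound 2 `COc1cc2nc(N3CCN(S(=O)(=O)c4ccc(S(C)(=O)=O)cc4)CC3)nc(N)c2cc1OC` gives 17000 nM. Compound 3 `COc1cc2nc(N3CCN(S(=O)(=O)c4ccc(C(C)(C)C)cc4)CC3)nc(N)c2cc1OC` gives 4100 nM, the lowest of the three: a 4.1-fold lower number from compound 2 to compound 3 (0.62 log units; beyond the scatter) and a 7.8-fold lower number from compound 1 to compound 3 (0.89 log units; beyond the scatter), both beyond the scatter, while a 1.9-fold lower number from compound 1 to compound 2 (0.27 log units; within the scatter) stays within it.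

Compound 4 `COc1cc2nc(N3CCN(S(=O)(=O)c4ccc(C(=O)O)cc4)CC3)nc(N)c2cc1OC` differs from compound 3 in one place: carboxy in place of tert-butyl on an aromatic carbon. Among the measured compounds shown here, of the measured steps, the one from compound 2 to compound 3 is the nearest analogy, where tert-butyl entered in place of methylsulfonyl at the same position and the number fell by a modest margin. The step from compound 1 to compound 3 points the same way. Here the tert-butyl leaves again and a carboxy enters, so a step back toward the numbers of compounds 1 and 2 is expected, of modest size and beyond the scatter; the estimated step is a 4.4-fold higher number from compound 3 to compound 4 (0.64 log units; beyond the scatter). For compound 4 the expected value in this assay is 18000 nM, in the range 6000 nM to 55000 nM.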

Compound 4, half-maximal inhibitory concentration: 53000 nM
Estimate against measurement, compound 4: 2.9-fold (0.47 log units) below; the range from low to high includes it.
By their numbers in this assay, from the lowest: compound 3; then compounds 2, 1 and 4 (each within the scatter of the next, the first and the last beyond it).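

In this assay, among the compounds shown here, carboxy at this aromatic carbon gives the only step graded large (a 13-fold higher number from compound 3 to compound 4 (1.11 log units; beyond the scatter)), so the low number of compound 3 is lost when tert-butyl is exchanged for this group. The same carbon also separates carboxy from methylsulfonyl (a 3.1-fold higher number from compound 2 to compound 4 (0.49 log units; beyond the scatter)), showing that the two groups tried in place of tert-butyl do not read alike. The 4-carboxyphenyl and 3-nitrophenyl arms, by contrast, remain within the scatter of each other (a 1.7-fold higher number from compound 1 to compound 4 (0.22 log units; within the scatter)), leaving compound 3 alone at the low end.

Open, on these data alone, is whether an isopropyl, a methyl or an amine at this carbon would keep the number of compound 3, and whether a methyl ester or primary amide would differ from the carboxy of compound 4. No measurement at hand accounts for these differences.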